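The source may hold more compounds than are shown below. What is called first, only, known or untested is meant among the compounds shown, and "the series" means these compounds.

Measured compounds in a functional assay on MCF7 cells (Homo sapiens) for antiproliferative activity, read by MTT assay, with a stated time of 24 h; a lower number here means a stronger inhibitor, a higher number a weaker inhibitor:
Compound 1, `CSc1nnc(COc2cc(C)c3c(C)cc(=O)oc3c2)o1`, sits at the limit > 100000 nM.
Compound 2, `CCSc1nnc(COc2cc(C)c3c(C)cc(=O)oc3c2)o1`, sits at the limit > 100000 nM.
Compound 3, `CCCCCCSc1nnc(COc2cc(C)c3c(C)cc(=O)oc3c2)o1`, sits at the limit > 100000 nM.

Compound 3 stands where every measured value stands, at the limit of > 100000 nM in this assay, at which 3 of the 3 values shown sit; none of the three is a number. Compound 4, `CCS(=O)(=O)c1nnc(COc2cc(C)c3c(C)cc(=O)oc3c2)o1`, differs from compound 3 by ethylsulfonyl in place of hexylsulfanyl on an aromatic carbon. The steps that could bear on it, a step that the two limits leave unreadable from compound 1 to compound 2, a step that the two limits leave unreadable from compound 1 to compound 3 and a step that the two limits leave unreadable from compound 2 to compound 3, each alter only the chain on the sulfur, and each is unreadable; both ends of each sit at the limit. Going by the values given here, no measured step exchanges a sulfanyl group for a sulfonyl group, so the change in compound 4 has no measured counterpart. Compound 4 is therefore expected to remain near the limit, with an estimated step of a number no higher from compound 3 to compound 4 (the limit leaves the size open). The estimate for compound 4 is 100000 nM, ranging from 30000 nM to 300000 nM.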

Compound 4, half-maximal inhibitory concentration: > 100000 nM
Compound 4: no number, only a limit (the forecaster's own chance of this, stated with the estimate: 75%); the middle value sits exactly at the limit.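

Going by these compounds alone, no step among compound 1, compound 2, compound 3 and compound 4 can be read, as each value is only a limit: the limit of > 100000 nM in this assay, at which 4 of the 4 values shown sit. The compounds shown leave open whether the chain on the sulfur or its oxidation level changes activity at all.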